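Hydroxy to Methoxy on a Cinnamoyl Cyclopentenedione Core

A few compounds are considered here, and "the series" means these few. Any claim that something is new, unique, unknown or untested is made for them only; others in the source may bear on it.

Of the compounds shown here, three sharing one core have been tested in an ADME assay on LLC-PK1 cells (Sus scrofa) for cytotoxicity, read by neutral red uptake; on this read-out lower numbers stand for stronger inhibition and higher numbers for weaker inhibition. Compound 1 `COC(/C=C/c1ccco1)=C1\C(=O)C=C(C)C1=O` gives 3.3 ug/mL, compound 3 `COC(/C=C/c1cccs1)=C1\C(=O)C=C(C)C1=O` gives 2.8 ug/mL, and compound 2 `CC1=CC(=O)/C(=C(O)/C=C/c2ccc(Cl)cc2)C1=O` gives 6 ug/mL. Compound 2 therefore holds the highest of the three numbers, although its gap to compound 1 lies within the scatter of repeated measurements, while its gap to compound 3 lies beyond it. Going by the values given here, the one measured step, a 1.2-fold lower number from compound 1 to compound 3 (0.07 log units; within the scatter), swaps one five-membered heteroaryl for another and does not touch the oxygen.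

Compound 4 `COC(/C=C/c1ccc(Cl)cc1)=C1\C(=O)C=C(C)C1=O` differs from compound 2 by a single change: methyl in place of hydrogen on an oxygen on an unsaturated carbon. Among the compounds with values here, no measured pair shows this hydroxy-to-methoxy change, so nothing directly anchors its size or direction. Compounds 1 and 3 carry the methoxy group and sit near compound 2, which suggests the change is small. Compound 4 is therefore expected to give about 4.5 ug/mL, within 2.2 ug/mL to 9 ug/mL, an expected step of a 1.3-fold lower number from compound 2 to compound 4 (0.12 log units; within the scatter) that stays within the scatter.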

Compound 4, half-maximal inhibitory concentration: 3.1 ug/mL
Compound 4: middle estimate off by 1.5-fold (0.16 log units), on the high side, within the range that was stated.
By their numbers in this assay, from the lowest: compounds 3, 4, 1 and 2 (each within the scatter of the next, the first and the last beyond it).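

Going by these compounds alone, this is the first direct reading of the hydroxy-to-methoxy change: in this assay, methyl in place of hydrogen on the oxygen gives a 1.9-fold lower number from compound 2 to compound 4 (0.29 log units; within the scatter) and so stays inside the spread of repeated measurements. At this place, then, the hydrogen of the hydroxy group can be exchanged for a methyl without a difference that this read-out can separate from scatter. Nothing shown here gives a reason for the size of this step.

From the compounds shown here alone, this rests on a single pair, so whether the change reads the same with the furan-2-yl of compound 1 or the thiophen-2-yl of compound 3 stays open. Also open, going by these compounds, is what an ethyl group, a longer chain or an acetyl group on that oxygen would do, or an amine in its place.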